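Swapping the pendant aryl group on the shared core

The compounds below may be only part of what the source reports. "The series", "measured", "known", "first", "only" and "open" are said of these compounds alone.

Measured compounds:
- Compound 1, `CC#CC(CC(=O)O)c1ccc(OCc2ccc3nc(-c4ccc(OC)cc4)cn3c2)cc1`: 47 nM
- Compound 2, `CC#CC(CC(=O)O)c1ccc(OCc2ccn3cc(-c4ccc(C)cc4)nc3c2)cc1`: 618 nM
- Compound 3, `CC#CC(CC(=O)O)c1ccc(OCc2ccc3nc(-c4ccc(C(C)C)cc4)cn3c2)cc1`: 528 nM

In an assay on isolated protein for agonist activity at Free fatty acid receptor 1 (Homo sapiens) (a lower number here means that less compound is needed, a higher number that more compound is needed for the effect), compound 2 gives the highest of the three numbers. Its value sits close to that of compound 3, within the scatter, while compound 1 lies far from it, beyond the scatter. Compound 4, `CC#CC(CC(=O)O)c1ccc(OCc2ccn3cc(-c4cc(F)ccc4F)nc3c2)cc1`, has not yet been measured. It differs from compound 2 in one place: 2,5-difluorophenyl in place of 4-methylphenyl on an aromatic carbon.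

Within the data shown here, only one measured step concerns a change on the pendant aryl group: an 11-fold higher number from compound 1 to compound 3 (1.05 log units; beyond the scatter). That step sits on the core of compound 1 rather than on the core of compound 2, and it exchanges a methoxy for an isopropyl, not a methyl for two fluorines, so it bears on the present change only loosely. It does show that a single substituent change on that ring can move the number a great deal. Among the measured compounds shown here, the data contain no step that points to a direction for compound 4, so the step of a 1.5-fold lower number from compound 2 to compound 4 (0.19 log units; within the scatter) is expected to be modest and uncertain. Compound 4 is therefore estimated at 400 nM, within a range from 100 nM to 1500 nM.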

Compound 4, half-maximal effective concentration: 639 nM
Compound 4: middle estimate off by 1.6-fold (0.20 log units), on the low side; low and high end bracket the measured number.
By their numbers in this assay, from the lowest: compound 1; then compounds 3, 2 and 4 (each within the scatter of the next).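

In this assay, placing 2,5-difluorophenyl where 4-methylphenyl stood, on the aromatic carbon of the five-membered ring, gives a 1.0-fold higher number from compound 2 to compound 4 (0.01 log units; within the scatter), so the two numbers cannot be told apart. Among these compounds, this is the only measured step on the core shared by compound 2 and compound 4, and it shows that on this core two quite different substituted phenyl groups can give matching numbers, whereas the one earlier step on the pendant aryl group, an 11-fold higher number from compound 1 to compound 3 (1.05 log units; beyond the scatter), lay on the core of compound 1 and went beyond the scatter. Nothing in the available data offers an explanation for this result.

Still open, as far as these compounds go, is whether 4-methoxyphenyl on the core of compound 2 would bring the number near that of compound 1, at 47 nM, or whether the effect of the methoxy group holds only on the core of compound 1. Equally open is how this position would respond to a pendant ring carrying a nitrile or a dimethylamino group, since the groups shown here are limited to alkyl, methoxy and fluorine substituents.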